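Working notes: imidazolyl for phenyl, compound 2 to compound 3

The compounds below may be only part of what the source reports. "The series", "measured", "known", "first", "only" and "open" are said of these compounds alone.

Compound 1 `COc1cccc(/C=C/C(=O)c2ccc(OC)c3c2OC(C)(C)C=C3)c1` — in a functional assay on SW-620 cells (Homo sapiens) for antiproliferative activity, read by MTT assay, with a stated time of 24 h (on this read-out higher numbers stand for weaker inhibition and lower numbers for stronger inhibition), compound 1 gives > 10000 nM, a limit of the assay.
Compound 2 `COc1ccc(C(=O)/C=C/c2ccc(-c3ccccc3)cc2)c2c1C=CC(C)(C)O2` — in this assay compound 2 gives > 10000 nM, likewise a limit.

Within the data shown here, compound 2 stands where every value so far stands, at the limit of > 10000 nM in this assay, at which 2 of the 2 values shown sit, so no number separates it from compound 1. Compound 3 `COc1ccc(C(=O)/C=C/c2ccc(-n3ccnc3)cc2)c2c1C=CC(C)(C)O2` differs from compound 2 by 1H-imidazol-1-yl in place of phenyl on an aromatic carbon; in words, 1H-imidazol-1-yl in place of phenyl on an aromatic carbon. Among the measured compounds shown here, no measured step covers this change, and the two limits point in no direction. The expected step that the limit leaves unreadable from compound 2 to compound 3 is none beyond the scatter. In this assay compound 3 is estimated at 12000 nM, with a range of 3000 nM to 40000 nM.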

Compound 3, half-maximal inhibitory concentration: > 10000 nM
Compound 3 ended at the assay's limit (the forecaster's own chance of this, stated with the estimate: 70%); the middle value is on the limit's open side.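

Compound 2 and compound 3 both rest at a limit of the assay, so no step can be read between them: the limit of > 10000 nM in this assay, at which 3 of the 3 values shown sit.

Left open is whether 1H-imidazol-1-yl in place of phenyl on an aromatic carbon changes anything in this assay.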